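Notes on the benzyl-amide series in the cell assay

The source may report more compounds than this note shows. Statements on the series, on what has been measured and on what is new or still open speak of the compounds shown alone.

In a functional assay on Maver1 cells (Homo sapiens) for inhibition, read by luminescence and CellTiter-Glo, with a stated time of 72 h (a lower number here means a stronger inhibitor, a higher number a weaker inhibitor), compound 1 `O=C(CCl)N1CCCC(n2nc(-c3ccc(Oc4ccccc4)cc3)cc2CO)C1` gives 1100 nM. Compound 2 `C=CC(=O)Nc1cccc(Cn2nc(-c3ccc(Oc4ccccc4)cc3)cc2C(=O)OCC)c1` gives 8600 nM in this assay, the higher of the two numbers, and its gap to compound 1 is beyond the scatter. Compound 3 `C=CC(=O)N1CCCC(n2nc(-c3ccc(Oc4ccccc4)cc3)cc2C(=O)OCC)C1` is reported in this assay only as a limit, > 60000 nM, not a number; this is the case of the limit of > 60000 nM in this assay, at which 1 of the 3 values shown sits.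

Compound 4 `C/C=C/C(=O)Nc1ccc(Cn2nc(-c3ccc(Oc4ccccc4)cc3)cc2C(=O)OCC)cc1` has not yet been measured. (4-(((prop-1-en-1-yl)carbonyl)amino)phenyl in place of 3-((vinylcarbonyl)amino)phenyl on a saturated chain carbon bound to an aromatic nitrogen). Among the measured compounds shown here, no step between measured compounds matching this change is available, so its size rests on expectation alone. Compound 4 is expected near 20000 nM, between 5000 nM and 60000 nM. The expected step of a 2.3-fold higher number from compound 2 to compound 4 (0.37 log units; beyond the scatter) is a weakening somewhat beyond the scatter, with a fair chance that only a limit is returned.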

Compound 4, half-maximal inhibitory concentration: > 60000 nM
Compound 4: a limit, no number (the forecaster's own chance of this, stated with the estimate: 25%); at least 3.0-fold (0.47 log units) between middle value and limit.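

Compound 4 is reported in this assay only as a limit, > 60000 nM, not a number. On a saturated chain carbon bound to an aromatic nitrogen, 4-(((prop-1-en-1-yl)carbonyl)amino)phenyl in place of 3-((vinylcarbonyl)amino)phenyl gives an at least 6.9-fold higher number from compound 2 to compound 4 (0.84 log units; beyond the scatter), the first sign that activity at this position responds to the aryl amide. The true size of this loss stays unknown, since the step ends at a limit: the limit of > 60000 nM in this assay, at which 2 of the 4 values shown sit.

The step changes the ring position and the chain together, so neither can be credited alone. A 4-((vinylcarbonyl)amino)phenyl group would separate them.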